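The compounds below may be only part of what the source reports. "The series", "measured", "known", "first", "only" and "open" are said of these compounds alone.

Measured so far:
compound 1 `Oc1cc(C(F)(F)F)ccc1-c1nc(-c2ccccc2O)n(-c2ccccc2Cl)n1` — in a functional assay on PC-12 cells (Rattus norvegicus) for cytotoxicity, read by MTT assay, with stated times of 2 h and 24 h, tested at 10 uM (on this read-out lower numbers stand for a weaker effect and higher numbers for a stronger effect at the one concentration tested), compound 1 gives 102%
compound 2 `Oc1cc(C(F)(F)F)ccc1-c1nc(-c2ccccc2O)n(-c2cccc(Cl)c2)n1` — in this assay compound 2 gives 100%

On the numbers shown, compound 2 carries the lower of the two values, but the one step onto it, a number 2 percentage points lower from compound 1 to compound 2 (within the scatter), lies within the scatter, so compound 1 and compound 2 are not told apart; both sit at close to the full effect at the single concentration tested.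

Compound 3 `Oc1cc(C(F)(F)F)ccc1-c1nc(-c2ccccc2O)n(-c2cc(F)cc(F)c2)n1` differs from compound 2 by 3,5-difluorophenyl in place of 3-chlorophenyl on an aromatic nitrogen. Among the measured compounds shown here, the only measured step that bears on this change is the one from compound 1 to compound 2, which also swapped the aryl group on the same aromatic nitrogen and came out as a number 2 percentage points lower from compound 1 to compound 2 (within the scatter), within the scatter. For the measured compounds named here, with both measured values near the top of the read-out and the one related step flat, no step beyond the scatter is expected in this assay. The step expected is a number 1 percentage points lower from compound 2 to compound 3 (within the scatter). For compound 3 the estimated value is 99%, with a range from 86% to 110%.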

Compound 3, a percentage reported as activity, at one concentration (the size of the read-out at that concentration, not a potency): 106%
Beside the measured number, compound 3's estimate is 7 percentage points below it, and the stated range covers the measured number.
By their numbers in this assay, from the lowest: compounds 2, 1 and 3 (each within the scatter of the next).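

With 3,5-difluorophenyl on the aromatic nitrogen, the read-out in this assay stays flat against both chlorinated aryl groups: the change from 3-chlorophenyl gives (a number 6 percentage points higher from compound 2 to compound 3 (within the scatter)), and the change from 2-chlorophenyl gives (a number 4 percentage points higher from compound 1 to compound 3 (within the scatter)). Among the compounds shown here, the earlier pair varied only where the chlorine sat on the aryl group, whereas these steps also change the halogen and its number, and still no step among the three compounds lies beyond the scatter. The three compounds therefore stand together at the single concentration tested, and no measurement at hand offers an explanation for this flat result.

Going by these compounds, it remains open whether the read-out would stay flat with a different kind of group on this nitrogen, such as an aryl ring bearing an amine or a carboxylic acid, or a plain alkyl chain in place of the aryl ring. Also open, on these data alone, are the effects of changing the hydroxyl groups or the trifluoromethyl group, which all three compounds carry unchanged, and whether these compounds would separate at another concentration.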